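The compounds below may be only part of what the source reports. "The series", "measured", "known", "first", "only" and "open" are said of these compounds alone.

In a functional assay on SK-OV-3 cells (Homo sapiens) for cytotoxicity (a lower number here means a stronger inhibitor, a higher number a weaker inhibitor), three compounds have been measured so far:

- compound 1 `O=C(CCCCCCc1nc2ccccc2[nH]1)NO` gives 2700 nM
- compound 2 `O=C(CCCCCCc1nc2ccc(F)cc2[nH]1)NO` gives 1900 nM
- compound 3 `O=C(CCCCCCc1nc2ccc(-c3ccc(F)cc3)cc2[nH]1)NO` gives 1200 nM

Compound 3 holds the lowest of the three numbers, though the step of a 1.6-fold lower number from compound 2 to compound 3 (0.20 log units; within the scatter) lies within the scatter, and only a 2.3-fold lower number from compound 1 to compound 3 (0.35 log units; beyond the scatter) goes beyond it. Compound 4 `O=C(CCCCCCc1nc2ccc(-c3cccc(F)c3)cc2[nH]1)NO` is the next compound: 3-fluorophenyl in place of 4-fluorophenyl on an aromatic carbon. Among the measured compounds shown here, no measured step moves the fluorine around the phenyl ring; the steps that bear on it, a 2.3-fold lower number from compound 1 to compound 3 (0.35 log units; beyond the scatter) and a 1.6-fold lower number from compound 2 to compound 3 (0.20 log units; within the scatter), only show what bringing in the 4-fluorophenyl did, and that gain was modest at most. Compound 4 is therefore expected to sit close to compound 3, with an estimated step of no change at the digits printed from compound 3 to compound 4 (within the scatter), none beyond the scatter. Compound 4 is estimated at 1200 nM, within 600 nM to 2400 nM.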

Compound 4, half-maximal inhibitory concentration: 1500 nM
Estimate against measurement, compound 4: 1.3-fold (0.10 log units) below; the measured number falls inside the stated range.
By their numbers in this assay, from the lowest: compounds 3, 4, 2 and 1 (each within the scatter of the next, the first and the last beyond it).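

In this assay, the step of a 1.3-fold higher number from compound 3 to compound 4 (0.10 log units; within the scatter) shows that moving the fluorine around the phenyl ring changes little at this position. Against hydrogen, the 3-fluorophenyl gives a 1.8-fold lower number from compound 1 to compound 4 (0.26 log units; within the scatter) and against fluoro it gives a 1.3-fold lower number from compound 2 to compound 4 (0.10 log units; within the scatter) so neither step clears the scatter, whereas the 4-fluorophenyl did clear it against hydrogen. No evidence is available to explain these small differences.

On these data alone, it remains open whether a methoxy group or an amine on the phenyl ring would give a step beyond the scatter from compound 3. As far as these compounds go, the effect of a shorter or longer chain is also open.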